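This account rests on a few compounds, and the source may have more. Where it says the series, first, only, none or still open, it means among the compounds named here.

Compound 1, `COc1cc(-c2nn(-c3cccc(NC(=O)c4cccc(C(F)(F)F)c4)c3)cc2-c2ccncc2)ccc1Cl`: > 50000 nM
Compound 2, `COc1cc(-c2nn(-c3cccc(NC(=O)Nc4cccc(C(F)(F)F)c4)c3)cc2-c2ccncc2)ccc1Cl`: 1650 nM
Compound 3, `COc1cc(-c2nn(-c3cccc(NC(=O)Nc4ccc(Cl)c(C(F)(F)F)c4)c3)cc2-c2ccncc2)ccc1Cl`: 4610 nM

In a functional assay on LOX IMVI cells (Homo sapiens) for inhibition, read by sulforhodamine B assay, with a stated time of 48 h (on this read-out higher numbers stand for weaker inhibition of growth and lower numbers for stronger inhibition of growth), compound 3 gives 4610 nM, the highest of the two numbers recorded. The nearest is compound 2, whose 1650 nM sits below it by a 2.8-fold higher number from compound 2 to compound 3 (0.45 log units; beyond the scatter). For compound 1 the reading is only the limit of > 50000 nM in this assay, at which 1 of the 3 values shown sits, and not a number, so compound 1 cannot be ranked against the other two beyond what the limit itself states. The two large steps measured, an at least 30-fold lower number from compound 1 to compound 2 (1.48 log units; beyond the scatter) and an at least 10-fold lower number from compound 1 to compound 3 (1.03 log units; beyond the scatter), both concern the substituent on the carbonyl carbon, and the modest step of a 2.8-fold higher number from compound 2 to compound 3 (0.45 log units; beyond the scatter) concerns a chloro on an aromatic carbon.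

Compound 4, `O=C(Nc1cccc(-n2cc(-c3ccncc3)c(-c3ccc(Cl)c(O)c3)n2)c1)Nc1ccc(Cl)c(C(F)(F)F)c1`, has not yet been measured. It differs from compound 3 in one place: hydrogen in place of methyl on an oxygen on an aromatic ring. Among the compounds with values here, none of the measured steps touches this oxygen or the ring it sits on, so they give no direct guidance on its effect, and an estimate can only rest on compound 3 itself. With no measured change at this position, no step beyond the scatter is expected in this assay. Compound 4 is therefore estimated to give 4600 nM, within a range from 1500 nM to 15000 nM. For compound 4 this estimate means a 1.0-fold lower number from compound 3 to compound 4 (0.00 log units; within the scatter).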

Compound 4, concentration for total growth inhibition: 1150 nM
Compound 4: the middle estimate sits 4.0-fold (0.60 log units) above what was measured; the measured number lies below the stated range.
By their numbers in this assay, from the lowest: compounds 4 and 2 (each within the scatter of the next); then compound 3. At a limit, above all of these: compound 1.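

In this assay, within the data shown here, the step of a 4.0-fold lower number from compound 3 to compound 4 (0.60 log units; beyond the scatter) gives the first reading for a change on the 4-chloro-3-methoxyphenyl ring. The earlier steps shown here concerned only the substituent on the carbonyl carbon and a chloro on an aromatic carbon, so they left this ring untested; now methoxy to hydroxy is seen to shift the number beyond the scatter, towards stronger inhibition of growth, with the loss of a single methyl. Nothing measured here bears on the reason for this step.

The compounds shown leave open whether removing this methyl would have a similar effect in compound 2, which lacks the chloro of compound 3 on the ring reached through the carbonyl carbon. They also leave open how an ethoxy, an amine or a carboxylic acid in place of the methoxy or hydroxy would read in this assay, and so whether the result belongs to the hydroxy group itself or simply to the departure of the methyl.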